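The source may report more compounds than this note shows. Statements on the series, on what has been measured and on what is new or still open speak of the compounds shown alone.

In a functional assay on NALM-6 cells (Homo sapiens) for cytotoxicity, read by MTT assay, with a stated time of 46 h (on this read-out lower numbers stand for stronger inhibition and higher numbers for weaker inhibition), the measured compounds are:

- Compound 1 `O=C1/C(=C/c2ccncc2)C(c2ccccc2)Oc2ccccc21`: 1600 nM
- Compound 2 `O=C1/C(=C\c2ccc(Cl)cc2)C(c2ccccc2)Oc2ccccc21`: > 1000000 nM

For compound 2, > 1000000 nM is a limit of the assay and not a number. Compound 3 `O=C1/C(=C/c2ccc(Cl)cc2)C(c2ccccc2)Oc2ccccc21` has the same atoms and bonds as compound 2, and the two compounds have the same atoms and bonds; at least one stereo element is drawn with a configuration in one of them and without one in the other: 1 of 2 stereo elements differ; a double bond is drawn Z in compound 2 and E in compound 3: a double bond is drawn Z in compound 2 and E in compound 3. Going by the values given here, the only actual number in this assay is that of compound 1, at 1600 nM, so the expectation leans towards that region. A large expected step towards stronger inhibition is estimated, an at least 160-fold lower number from compound 2 to compound 3 (2.22 log units; beyond the scatter). For compound 3 the estimate is 6000 nM, with an expected range of 1000 nM to 40000 nM.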

Compound 3, half-maximal inhibitory concentration in the NALM-6 assay: 7400 nM
Estimate against measurement, compound 3: 1.2-fold (0.09 log units) below; the range from low to high includes it.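

In the NALM-6 assay compound 2 gives > 1000000 nM, which is a limit of the assay and not a number. In the NALM-6 assay, changing only the double bond geometry gives an at least 130-fold lower number from compound 2 to compound 3 (2.13 log units; beyond the scatter). In a physicochemical assay for lipophilicity, read by HPLC (a lower number here means a more polar compound, a higher number a more lipophilic compound), compound 2 gives 4.53 and compound 3 gives 4.46, and the same change gives a number 0.07 log units lower from compound 2 to compound 3 (within the scatter). With the geometry kept, in the NALM-6 assay 4-chlorophenyl in place of pyridin-4-yl gives a smaller change, a 4.6-fold higher number from compound 1 to compound 3 (0.67 log units; beyond the scatter).

From the compounds shown here alone, it stays open whether compounds carrying pyridin-4-yl depend on the double bond geometry in the same way. Going by these compounds, how an amine or a carboxylic acid in place of 4-chlorophenyl would read in the NALM-6 assay also stays open.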